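This account rests on a few compounds, and the source may have more. Where it says the series, first, only, none or still open, it means among the compounds named here.

Compounds 1, 2 and 3 share one core and vary only on a saturated chain carbon bound to an aromatic carbon and a saturated chain carbon. In a functional assay on CHO cells for antagonist activity at prostaglandin E2 receptor EP3 subtype (Homo sapiens), read by cAMP accumulation (a higher number here means a weaker inhibitor, a lower number a stronger inhibitor), compound 1 `CC(C)C(Cc1nnc[nH]1)c1ccc(-c2ccc3cccc(F)c3c2)[nH]c1=O` gives 17 nM. Compound 2 `CC(C)C(Nc1nccs1)c1ccc(-c2ccc3cccc(F)c3c2)[nH]c1=O` gives 10 nM in this assay. Compound 3 `CC(C)C(c1ccc(-c2ccc3cccc(F)c3c2)[nH]c1=O)N1CCNC1=O` gives 28 nM in this assay, the highest of the three numbers: a 1.6-fold higher number from compound 1 to compound 3 (0.22 log units; within the scatter), and a 2.8-fold higher number from compound 2 to compound 3 (0.45 log units; beyond the scatter). Compound 4 `CC(C)NC(=O)CC(c1ccc(-c2ccc3cccc(F)c3c2)[nH]c1=O)C(C)C` carries (isopropylcarbamoyl)methyl in place of 2-oxoimidazolidin-1-yl on a saturated chain carbon bound to an aromatic carbon and a saturated chain carbon. Every measured step changes this same place, and all stayed small: a 1.7-fold lower number from compound 1 to compound 2 (0.23 log units; within the scatter), together with the two steps into compound 3 already noted. An open-chain amide is untried here, so the expected step of a 1.1-fold lower number from compound 3 to compound 4 (0.05 log units; within the scatter) is small, with no direction beyond the scatter. Compound 4 is estimated at 25 nM, range 8 nM to 80 nM.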

Compound 4, half-maximal inhibitory concentration: 15 nM
The estimate for compound 4 lay 1.7-fold (0.22 log units) above the measured number; the range from low to high includes it.
By their numbers in this assay, from the lowest: compounds 2, 4, 1 and 3 (each within the scatter of the next, the first and the last beyond it).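

The open-chain (isopropylcarbamoyl)methyl group, which has no ring, keeps this position in the same range in this assay (a 1.9-fold lower number from compound 3 to compound 4 (0.27 log units; within the scatter); a 1.5-fold higher number from compound 2 to compound 4 (0.18 log units; within the scatter); a 1.1-fold lower number from compound 1 to compound 4 (0.05 log units; within the scatter)). A ring in the group on this saturated chain carbon is therefore not required here, and of the four compounds only compound 2 and compound 3 stand apart beyond the scatter. No evidence accompanies these numbers to explain them.

Still open, as far as these compounds go, is whether a carboxylic acid, a primary amine or a longer chain on the amide nitrogen would stay in this range at the same carbon.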